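The source may hold more compounds than are shown below. What is called first, only, known or untested is meant among the compounds shown, and "the series" means these compounds.

Within the data shown here, compound 2, `COc1ccc2nc(C)cc(OCC(=O)Nc3ccc(F)cc3)c2c1`, is the lower of the two measured members in a physicochemical assay for lipophilicity, read by HPLC, in phosphate buffer, measured as chromatographic lipophilicity, at pH 7.4 (a lower number here means a more polar compound, a higher number a more lipophilic compound), giving 4.49. Among the measured compounds shown here, compound 1, `COc1ccc2nc(C)cc(OCC(=O)Nc3cc(C)c(F)c(C)c3)c2c1`, gives 5.5 in this assay, and the only measured step, a number 1.01 log units lower from compound 1 to compound 2 (beyond the scatter), is the one that separates the two: a reading that two methyl groups leaving the aryl amide contribute a large shift in this assay.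

Compound 3, `COc1ccc2nc(C)cc(OCC(=O)Nc3ccncc3)c2c1`, is not yet measured. It differs from compound 2 by pyridin-4-yl in place of 4-fluorophenyl on an amide-type nitrogen. For the measured compounds named here, no measured step covers an aryl-to-pyridinyl exchange, so the direction and size of the step are read only from the change itself: a fluorine is lost and a ring nitrogen that counts as one hydrogen-bond acceptor enters, which in this assay is expected to read as a lower number, and by a step larger than the one from compound 1 to compound 2. For compound 3 the expected step is a number 1.59 log units lower from compound 2 to compound 3 (beyond the scatter). Compound 3 is therefore estimated at 2.9 in this assay, within a range of 2.3 to 3.5.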

Compound 3, distribution coefficient: 2.5
Compound 3: the middle estimate sits 0.40 log units above what was measured, within the range that was stated.
By their numbers in this assay, from the lowest: compound 3; then compound 2; then compound 1.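

In this assay, pyridin-4-yl on the amide-type nitrogen gives a number 1.99 log units lower from compound 2 to compound 3 (beyond the scatter), so exchanging the ring itself moves the number at this position, whereas the earlier pair varied only the groups carried by a carbon-only ring. That step exceeds a number 1.01 log units lower from compound 1 to compound 2 (beyond the scatter), and the full span now seen at this one place is a number 3.00 log units lower from compound 1 to compound 3 (beyond the scatter), which makes the group on this nitrogen a strong determinant of the reading across these three compounds. The step from 4-fluorophenyl to pyridin-4-yl changes two things together, the loss of the fluorine and the entry of the ring nitrogen, and no measurement shown here explains the size of the step.

Plain phenyl on the same nitrogen would separate the share of the fluorine from that of the ring nitrogen, and a pyridin-4-yl ring carrying two methyl groups would test whether those groups shift the number by a similar amount on that ring. From the compounds shown here alone, an amine or a carboxylic acid on the ring, both of which could carry a charge at the assay pH, also remains open, as does any change to the shared core or to the chain linking it to the amide.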